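Ester chain length and cytotoxicity in a cytidine ester series

The source may report more compounds than this note shows. Statements on the series, on what has been measured and on what is new or still open speak of the compounds shown alone.

Measured compounds:
Compound 1, `C=CCCCCCCCCC(=O)O[C@H]1[C@H](O)[C@H](n2ccc(N)nc2=O)O[C@@H]1CO`, gives 0.05 ug/mL in a functional assay on HeLa cells (Homo sapiens) for cytotoxicity, read by cell counting, with a stated time of 48 h; a higher number here means that more compound is needed for the effect, a lower number that less compound is needed.
Compound 2, `CCCCCCCCCCCCCCCCCC(=O)O[C@H]1[C@H](O)[C@H](n2ccc(N)nc2=O)O[C@@H]1CO`, gives 0.13 ug/mL in this assay.
Compound 3, `CCCCCCCCCCC(=O)O[C@H]1[C@H](O)[C@H](n2ccc(N)nc2=O)O[C@@H]1CO`, gives 0.04 ug/mL in this assay.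

Compound 3 has the lowest of the three numbers. The step of a 1.3-fold lower number from compound 1 to compound 3 (0.10 log units; within the scatter) lies within the scatter, so no order between compound 1 and compound 3 is claimed. The step of a 3.3-fold lower number from compound 2 to compound 3 (0.51 log units; beyond the scatter) lies beyond the scatter, as does a 2.6-fold higher number from compound 1 to compound 2 (0.41 log units; beyond the scatter); in both, a longer chain goes with a higher number.

Compound 4, `CCCCCCCCCCCCCC(=O)O[C@H]1[C@H](O)[C@H](n2ccc(N)nc2=O)O[C@@H]1CO`, differs from compound 3 in one place: propyl in place of hydrogen on a saturated chain carbon, ten or more bonds along the chain from a carbonyl carbon. The step from compound 2 to compound 3 concerns the same place and the same direction of change reversed: removing heptyl there lowered the number, so adding propyl there is expected to raise it, though by less, since propyl is shorter than heptyl and compound 4 sits between compound 3 and compound 2 in chain length. The step from compound 1 to compound 2 points the same way. An upward step of modest size, near the edge of the scatter, is therefore expected in this assay: a 1.5-fold higher number from compound 3 to compound 4 (0.18 log units; within the scatter). Compound 4 is estimated at 0.06 ug/mL, with a range from 0.03 ug/mL to 0.12 ug/mL.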

Compound 4, concentration for half-maximal effect: 0.08 ug/mL
The estimate for compound 4 lay 1.3-fold (0.12 log units) below the measured number; the measured number falls inside the stated range.
By their numbers in this assay, from the lowest: compounds 3, 1, 4 and 2 (each within the scatter of the next, the first and the last beyond it).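

In this assay, propyl in place of hydrogen on a saturated chain carbon, ten or more bonds along the chain from a carbonyl carbon, gives a 2.0-fold higher number from compound 3 to compound 4 (0.30 log units; within the scatter) and so does not separate from the scatter, unlike the larger change with heptyl, a 3.3-fold lower number from compound 2 to compound 3 (0.51 log units; beyond the scatter) for that step. Compound 4 also stays within the scatter of both other neighbours, with a 1.6-fold lower number from compound 2 to compound 4 (0.21 log units; within the scatter) on one side and a 1.6-fold higher number from compound 1 to compound 4 (0.20 log units; within the scatter) on the other, so the one clear gap among the saturated chains, between compound 2 and compound 3, now resolves into smaller steps that cannot be told from the scatter individually. No measurement at hand bears on why the number follows chain length in this way.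

Going by these compounds, whether a chain longer than that of compound 2 continues the upward direction remains open, as does the point at which the chain could be shortened before the number changes. Also open, on these data alone, is how a hydroxyl group, an amine or a carboxylic acid at the far end of the chain would compare with the plain saturated chains.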